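Urea to amide: a one-group change with no direct precedent

The compounds below may be only part of what the source reports. "The series", "measured", "known", "first", "only" and "open" are said of these compounds alone.

In a functional assay on MDA-MB-468 cells (Homo sapiens) for inhibition, read by sulforhodamine B assay, with a stated time of 48 h, tested at 10 uM (a lower number here means a stronger effect, a higher number a weaker effect of the compound at the concentration tested), two compounds from one series have been measured so far. Compound 1 `COc1cc(Cl)cc(-c2nn(-c3cccc(NC(=O)Nc4ccc(Cl)c(C(F)(F)F)c4)c3)cc2-c2ccncc2)c1` gives -14.4% in this assay. Going by the values given here, compound 2 `COc1cc(Cl)cc(-c2nn(-c3cccc(NC(=O)Nc4cccc(C(F)(F)F)c4)c3)cc2-c2ccncc2)c1` gives 6.89% in this assay, which is the higher of the two numbers, its only neighbour being compound 1. Among the compounds with values here, the single measured step, a number 21.3 percentage points higher from compound 1 to compound 2 (beyond the scatter), came from a hydrogen in place of chloro on an aromatic carbon, so it tells about that change alone.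

Compound 3 `COc1cc(Cl)cc(-c2nn(-c3cccc(NC(=O)c4cccc(C(F)(F)F)c4)c3)cc2-c2ccncc2)c1` differs from compound 2 in another way: 3-(trifluoromethyl)phenyl in place of (3-(trifluoromethyl)phenyl)amino on a carbonyl carbon. Within the data shown here, no measured step concerns this kind of change; the step between compound 1 and compound 2 leaves the urea untouched and so does not bear on it. With nothing in the data to point in either direction, compound 3 is expected to sit near compound 2, with a step of a number 5.1 percentage points higher from compound 2 to compound 3 (within the scatter) that is likely to stay within the scatter. Compound 3 is therefore estimated at 12% in this assay, within a range from -12% to 36%.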

Compound 3, a percentage reported as activity, at one concentration (the size of the read-out at that concentration, not a potency): 47%
The estimate for compound 3 lay 35 percentage points below the measured number; measured number outside the range, above it.
By their numbers in this assay, from the lowest: compound 1; then compound 2; then compound 3.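

This change shows that the linkage on the carbonyl carbon matters more in this assay than the earlier chloro step could suggest: with 3-(trifluoromethyl)phenyl in place of (3-(trifluoromethyl)phenyl)amino, the result is a number 40.1 percentage points higher from compound 2 to compound 3 (beyond the scatter), a large move towards a weaker effect at the concentration tested, whereas the earlier step, a number 21.3 percentage points higher from compound 1 to compound 2 (beyond the scatter), was modest. The widest gap in the series is a number 61.4 percentage points higher from compound 1 to compound 3 (beyond the scatter), also large, and this step removes the chloro together with the amino nitrogen, so it cannot assign a share to either one. The group that leaves counts one hydrogen-bond donor and the group that enters counts none, but no available measurement connects that difference to the result.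

Going by these compounds, it remains open whether the amino nitrogen itself is what counts, a question that a carbamate oxygen or a methylene on the carbonyl carbon in place of that nitrogen would address. On these data alone, it also remains open whether 4-chloro-3-(trifluoromethyl)phenyl on the carbonyl carbon of the amide would give a stronger effect than compound 3 does.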